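A few compounds are considered here, and "the series" means these few. Any claim that something is new, unique, unknown or untested is made for them only; others in the source may bear on it.

Three compounds here share one core, and they differ only in the group on the outer benzene ring. Compound 1 `CNc1nc(NCc2ccc(OC(F)(F)F)cc2)cc(-c2ccccn2)n1` carries trifluoromethoxy there, and in a functional assay on HEK293 cells for agonist activity at G-protein coupled receptor 39 (Homo sapiens), read by inositol phosphate accumulation (on this read-out lower numbers stand for an effect already at smaller amounts and higher numbers for an effect only at larger amounts of compound), compound 1 gives 13 nM. Compound 2 `CNc1nc(NCc2ccc(NC(C)=O)cc2)cc(-c2ccccn2)n1` carries acetamido; in this assay compound 2 gives 5 nM, and the change is a 2.6-fold lower number from compound 1 to compound 2 (0.41 log units; beyond the scatter). Compound 3 `CNC(=O)c1ccc(CNc2cc(-c3ccccn3)nc(NC)n2)cc1` carries methylcarbamoyl; in this assay compound 3 gives 30 nM, the highest of the three numbers, reached through a 2.3-fold higher number from compound 1 to compound 3 (0.36 log units; beyond the scatter) and a 6.0-fold higher number from compound 2 to compound 3 (0.78 log units; beyond the scatter).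

Compound 4 `CNc1nc(NCc2ccc(NS(C)(=O)=O)cc2)cc(-c2ccccn2)n1` follows from compound 3 by one change: methanesulfonamido in place of methylcarbamoyl on an aromatic carbon. The most telling measured step is a 6.0-fold higher number from compound 2 to compound 3 (0.78 log units; beyond the scatter), and acetamido in compound 2 resembles the entering methanesulfonamido in that both are linked to the ring through nitrogen. The weaker comparison is a 2.3-fold higher number from compound 1 to compound 3 (0.36 log units; beyond the scatter). On this basis compound 4 is expected to move back toward a lower number, by about a 3.0-fold lower number from compound 3 to compound 4 (0.48 log units; beyond the scatter). The estimated value for compound 4 in this assay is 10 nM, with a likely range from 3 nM to 30 nM.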

Compound 4, half-maximal effective concentration: 3 nM
Compound 4: the middle estimate sits 3.3-fold (0.52 log units) above what was measured; the measured number falls inside the stated range.
By their numbers in this assay, from the lowest: compounds 4 and 2 (each within the scatter of the next); then compound 1; then compound 3.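

Replacing acetyl with methylsulfonyl on the ring nitrogen does not separate compound 2 from compound 4 in this assay, with a 1.7-fold lower number from compound 2 to compound 4 (0.22 log units; within the scatter), so this position accepts either group on that nitrogen. The nitrogen-linked methanesulfonamido of compound 4 also stands clear of the other two groups, with a 10-fold lower number from compound 3 to compound 4 (1.00 log units; beyond the scatter) and a 4.3-fold lower number from compound 1 to compound 4 (0.64 log units; beyond the scatter), which extends the earlier contrast: among these four compounds, the two groups linked through nitrogen give the two lowest numbers, and no compound goes against this. Nothing available here explains these differences.

The compounds shown leave open whether the nitrogen link alone is enough, which a plain amine at this position would test. They also leave open how much room there is beyond the sulfonyl, as a longer chain such as ethanesulfonamido would show.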